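Piperidin-1-yl gives way to (3-chlorophenyl)amino

The compounds below may be only part of what the source reports. "The series", "measured", "known", "first", "only" and "open" are said of these compounds alone.

Compound 1 `O=C1C=C(Nc2ccc(Br)cc2)C(=O)c2c1nc1n2[C@H]2OC[C@@H](O)[C@H]2OC1`: 2850 nM
Compound 2 `O=C1C=C(N2CCCCC2)C(=O)c2c1nc1n2[C@H]2OC[C@@H](O)[C@H]2OC1`: > 8000 nM (a limit, not a number)

Both compounds share one core and were tested in a functional assay on ECa-109 cells for inhibition, with ECa-109 cell line (Homo sapiens) as the target, read by sulforhodamine B assay; a lower number here means a stronger inhibitor, a higher number a weaker inhibitor. Compound 2 stands at a limit and not at a number: > 8000 nM.

Compound 3 `O=C1C=C(Nc2cccc(Cl)c2)C(=O)c2c1nc1n2[C@H]2OC[C@@H](O)[C@H]2OC1` has not yet been measured. It carries (3-chlorophenyl)amino in place of piperidin-1-yl on a double-bonded ring carbon.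

Among the compounds with values here, only one measured step bears on this change: an at least 2.8-fold higher number from compound 1 to compound 2 (0.44 log units; beyond the scatter). Within the data shown here, that step lies beyond the scatter, and it is the only such comparison available, so the evidence is thin. Compound 3 regains a phenyl ring on an amino group, as in compound 1, so the change is expected to run in the opposite direction, towards a lower number and a stronger inhibitor. The likely landing point is close to compound 1 at 2850 nM. The expected change is an at least 2.8-fold lower number from compound 2 to compound 3 (0.45 log units; beyond the scatter). For compound 3, the estimated value is 2800 nM, with an expected range from 1000 nM to 7000 nM.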

Compound 3, half-maximal inhibitory concentration: 4690 nM
The estimate for compound 3 lay 1.7-fold (0.22 log units) below the measured number; measured number inside the range.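

In this assay, putting (3-chlorophenyl)amino in place of piperidin-1-yl on this double-bonded ring carbon gives an at least 1.7-fold lower number from compound 2 to compound 3 (0.23 log units; that floor lies within the scatter). That figure is only a floor on the size of the step, since compound 2 is pinned down by nothing more than a limit: the limit of > 8000 nM in this assay, at which 1 of the 3 values shown sits. Swapping the aryl group on the amine nitrogen, with 3-chlorophenyl in place of 4-bromophenyl, gives a 1.6-fold higher number from compound 1 to compound 3 (0.22 log units; within the scatter), so at this position two different halogen-bearing phenyl rings cannot be told apart in this assay.

Compound 1 and compound 3 both carry an aromatic ring and an amine hydrogen, while compound 2 has neither, so the compounds shown do not reveal which of the two features matters. A cyclohexylamino group would keep the amine hydrogen without the aromatic ring, and a methyl(phenyl)amino group would keep the aromatic ring without that hydrogen, so these two groups would pull the features apart.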